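Homologation beside the trimethoxyphenyl lactam: methoxy versus methylsulfanyl

The compounds below may be only part of what the source reports. "The series", "measured", "known", "first", "only" and "open" are said of these compounds alone.

Compound 1 `C=CC1C(=O)N(c2cc(OC)c(OC)c(OC)c2)C1c1ccc(OC)cc1` gives 33 nM in a functional assay on HL-60 cells (Homo sapiens) for inhibition, read by resazurin assay, with a stated time of 72 h; a higher number here means a weaker inhibitor, a lower number a stronger inhibitor. Compound 3 `C=CC1C(=O)N(c2cc(OC)c(OC)c(OC)c2)C1c1ccc(OCC)cc1`, which carries methyl in place of hydrogen on a saturated chain carbon bound to an oxygen on an aromatic ring, gives 35 nM in this assay, a step of a 1.1-fold higher number from compound 1 to compound 3 (0.03 log units; within the scatter). Compound 2 `COc1cc(N2C(=O)C(C3CC3)C2c2ccc(SC)cc2)cc(OC)c1OC` gives 279 nM in this assay; the difference between its core and the core of compound 1 is not broken down here. Compound 4 `CCSc1ccc(C2C(C3CC3)C(=O)N2c2cc(OC)c(OC)c(OC)c2)cc1` carries methyl in place of hydrogen on a saturated chain carbon bound to a sulfur. This is the same kind of change as from compound 1 to compound 3, though the place differs: there the carbon is bound to an oxygen on an aromatic ring, here to a sulfur. Because a 1.1-fold higher number from compound 1 to compound 3 (0.03 log units; within the scatter) sits within the scatter, a step of about a 1.0-fold higher number from compound 2 to compound 4 (0.00 log units; within the scatter) is expected from compound 2 to compound 4. Compound 4 is estimated at 280 nM, between 130 nM and 600 nM.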

Compound 4, half-maximal inhibitory concentration: 803 nM
Compound 4: middle estimate off by 2.9-fold (0.46 log units), on the low side, outside the stated range (above it).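

In this assay, methyl in place of hydrogen on a saturated chain carbon bound to a sulfur gives a 2.9-fold higher number from compound 2 to compound 4 (0.46 log units; beyond the scatter), so methylsulfanyl to ethylsulfanyl weakens inhibition on this core. The same kind of change therefore did not carry over with the same size from one core to the other: the same change on two cores in this assay, a 1.1-fold higher number (0.03 log units; within the scatter) from compound 1 to compound 3 and a 2.9-fold higher number (0.46 log units; beyond the scatter) from compound 2 to compound 4, 2.7-fold (0.43 log units) apart, beyond the scatter of two such steps. This rests on a single pair per core, and it does not show which of the differences between the two cores separates the steps, or whether a third core would follow either one.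

The compounds shown leave open how a longer chain, such as propyl, would read on the oxygen or the sulfur. From the compounds shown here alone, how methoxy and methylsulfanyl compare on one shared core also remains open.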